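Replacing the aryl group on the carbonyl of a thiocarbamate series

The source may hold more compounds than are shown below. What is called first, only, known or untested is meant among the compounds shown, and "the series" means these compounds.

Compound 1 `O=C1c2ccccc2C(=O)N1CCOC(=S)N(C(=O)c1ccccc1[N+](=O)[O-])c1ccc(Cl)cc1`: in an ADME assay on MT4 cells (Homo sapiens) for cytotoxicity, read by MTT assay (on this read-out higher numbers stand for lower toxicity in this test and lower numbers for higher toxicity in this test), compound 1 gives 21000 nM.
Compound 2 `Cc1ccc(C(=O)N(C(=S)OCCN2C(=O)c3ccccc3C2=O)c2ccc(Cl)cc2)cc1`: compound 2 reaches only a limit of the test, > 100000 nM.
Compound 3 `Cc1ccc(C(=O)N(C(=S)OCCN2C(=O)c3ccccc3C2=O)c2ccc(C)cc2)cc1`: compound 3 gives 83000 nM.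

Compound 3 stands at the highest of the two numbers actually read; compound 1 sits lower, and compound 2 reports only (the limit of > 100000 nM in this assay, at which 1 of the 3 values shown sits). Compound 4 `COc1cccc(OC)c1C(=O)N(C(=S)OCCN1C(=O)c2ccccc2C1=O)c1ccc(C)cc1` is not yet measured. It differs from compound 3 in one place: 2,6-dimethoxyphenyl in place of 4-methylphenyl on a carbonyl carbon. One measured step also changes the group on the carbonyl carbon, an at least 4.7-fold higher number from compound 1 to compound 2 (0.67 log units; beyond the scatter), and it moved the number beyond the scatter. The other step, an at least 1.2-fold lower number from compound 2 to compound 3 (0.08 log units; that floor lies within the scatter), touches a different ring and stays within the scatter. The two steps show that the group on the carbonyl carbon matters, but nothing among them shows which way a 2,6-dimethoxyphenyl moves the number. A small drop or no change beyond the scatter is therefore expected, with a fair chance that compound 4 again reaches the limit. The estimate for compound 4 in this assay is 60000 nM, expected to fall between 20000 nM and 150000 nM. The expected step is a 1.4-fold lower number from compound 3 to compound 4 (0.14 log units; within the scatter).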

Compound 4, half-maximal cytotoxic concentration: 36000 nM
Compound 4: middle estimate off by 1.7-fold (0.22 log units), on the high side; the measured number falls inside the stated range.
By their numbers in this assay, from the lowest: compounds 1 and 4 (each within the scatter of the next); then compound 3. At a limit, above all of these: compound 2.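

Exchanging 4-methylphenyl for 2,6-dimethoxyphenyl on the carbonyl carbon gives a 2.3-fold lower number from compound 3 to compound 4 (0.36 log units; beyond the scatter), so this change means higher toxicity in this assay. For the compounds shown here, compound 2 stands at a limit, so the earlier step at this position gave only a floor; here both numbers are actual readings, and a change on the carbonyl carbon has a measured size for the first time. Nothing given here accounts for the shift.

Open, from the compounds shown here alone, is whether both methoxy groups are needed for the shift, which a phenyl ring carrying a single methoxy group could help to settle. Also open, going by these compounds, is how the number responds when the aryl group on the carbonyl carbon gives way to something other than a ring, such as a short alkyl chain or an amine.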